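Replacing the Methylthiophene of Compound 1 with an Iodothiophene

A few compounds are considered here, and "the series" means these few. Any claim that something is new, unique, unknown or untested is made for them only; others in the source may bear on it.

Of the compounds shown here, three have been measured so far in a functional assay on HUVEC cells (Homo sapiens), read by BrdU incorporation, with a stated time of 72 h (on this read-out lower numbers stand for stronger inhibition and higher numbers for weaker inhibition), and they share one general shape. Compound 1 (`Cc1ccc2nc(Cl)c(/C=C/C(=O)c3sccc3C)cc2c1`) gives 127 nM and thus stands within the scatter of compound 2 (`Cc1cccc2cc(/C=C/C(=O)c3ccc(Br)s3)c(Cl)nc12`) at 243 nM in the same test. Compound 3 (`Cc1ccc2cc(/C=C/C(=O)c3ccc(Cl)s3)c(Cl)nc2c1`) gives a lower number of 49.5 nM that lies beyond the scatter from compound 1.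

The next compound, compound 4 (`Cc1ccc2nc(Cl)c(/C=C/C(=O)c3ccc(I)s3)cc2c1`), keeps the core of compound 1 but has 5-iodothiophen-2-yl in place of 3-methylthiophen-2-yl on a carbonyl carbon. Among the measured compounds shown here, no measured pair isolates this change. Compound 2 and compound 3 both carry a halogen on their thiophene, but compound 2 gives 243 nM and compound 3 gives 49.5 nM on different cores, so they offer only loose guidance. A modest shift toward a lower number is expected, an estimated step of a 1.5-fold lower number from compound 1 to compound 4 (0.17 log units; within the scatter) (probably within the scatter). For compound 4 the estimated value in this assay is 85 nM (expected range 28 nM to 260 nM).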

Compound 4, half-maximal inhibitory concentration: 129 nM
Estimate against measurement, compound 4: 1.5-fold (0.18 log units) below, and the stated range covers the measured number.
By their numbers in this assay, from the lowest: compound 3; then compounds 1, 4 and 2 (each within the scatter of the next).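

In this assay, putting 5-iodothiophen-2-yl in place of 3-methylthiophen-2-yl on a carbonyl carbon gives a 1.0-fold higher number from compound 1 to compound 4 (0.01 log units; within the scatter). Among the compounds shown here, this is the first pair that differs in one place, and it shows that on the core of compound 1 this read-out does not separate the two substituted thiophenes, even though the substituent and its place on the ring both differ. Nothing at hand says why the two groups read alike.

Going by these compounds, whether the thiophene would still read the same carrying an amine or a carboxylic acid in place of the iodine remains open. Also open, on these data alone, is what sets compound 3 apart, as it differs from compound 4 in more than one place and that comparison cannot be read.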